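A few compounds are considered here, and "the series" means these few. Any claim that something is new, unique, unknown or untested is made for them only; others in the source may bear on it.

Measured so far in a functional assay on HeLa S3 cells (Homo sapiens) for antiproliferative activity, read by XTT assay, with a stated time of 72 h; a higher number here means a weaker inhibitor, a lower number a stronger inhibitor:
- compound 1 `CSc1ncnc2c1c(-c1cccs1)cn2[C@@H]1O[C@H](CO)[C@@H](O)[C@H]1O`: 1960 nM
- compound 2 `CSc1ncnc2c1c(-c1ccsc1)cn2[C@@H]1O[C@H](CO)[C@@H](O)[C@H]1O`: > 20000 nM (a limit)

Among the compounds with values here, compound 1 holds the only actual number. Compound 2 gives only a limit, > 20000 nM.

Compound 3 `Cc1ncnc2c1c(-c1cccs1)cn2[C@@H]1O[C@H](CO)[C@@H](O)[C@H]1O` keeps the thiophen-2-yl of compound 1 and differs from it in one group: methyl in place of methylsulfanyl on an aromatic carbon. The change is methyl in place of methylsulfanyl on an aromatic carbon.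

Within the data shown here, the single measured step, an at least 10-fold higher number from compound 1 to compound 2 (1.00 log units; beyond the scatter), replaces thiophen-2-yl with thiophen-3-yl and leaves the methylsulfanyl group untouched. It shows that one substitution can move this series well beyond the scatter, but it gives neither a size nor a direction for the change at hand. A step beyond the scatter in this assay therefore remains possible either way, although none is favoured, and the central expectation is no clear shift.

The estimate for the step is a 1.0-fold higher number from compound 1 to compound 3 (0.01 log units; within the scatter). Compound 3 is expected at 2000 nM, with an estimated range of 300 nM to 15000 nM.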

Compound 3, half-maximal inhibitory concentration: > 15000 nM
Compound 3: a limit, no number; the forecaster's own chance of this, stated with the estimate: 20%; middle value at least 7.5-fold (0.87 log units) from the limit.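

In this assay, methyl in place of methylsulfanyl, on the aromatic carbon next to the ring nitrogen, gives an at least 7.6-fold higher number from compound 1 to compound 3 (0.88 log units; beyond the scatter). Compound 3 gives a limit and not a number: the limit of > 15000 nM in this assay, at which 1 of the 3 values shown sits. This is the first measured change at this position, and it shows that the position is not indifferent: replacing methylsulfanyl with methyl moves the read-out beyond the scatter, just as the change from thiophen-2-yl to thiophen-3-yl did at the other site, so each of the two single changes shown leaves compound 1 as the only compound with an actual number.

The size of the step has only a lower bound, since the value of compound 3 lies somewhere past its limit, and the compounds shown give no reason for the shift. On these data alone, whether the sulfur atom, the length of the chain or something else matters remains open, and an amine, a methoxy group or a longer chain such as ethylsulfanyl at this position would be needed to tell whether any other group keeps a measurable value in this assay.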